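Replacing 1,3-oxazol-4-yl in compound 3

The source may hold more compounds than are shown below. What is called first, only, known or untested is meant among the compounds shown, and "the series" means these compounds.

In an ADME assay on the whole organism (strain 129/SvEvBrd x C57BL/6) for metabolic stability, with Mus musculus as the target (on this read-out higher numbers stand for a longer-lived compound and lower numbers for a shorter-lived compound), compound 1 (`CC(O)c1nc([C@@H](O)[C@H](O)[C@H](O)CO)c[nH]1`) gives 4.4 h as its value. Compound 3 (`OC[C@@H](O)[C@@H](O)[C@H](O)c1c[nH]c(-c2cocn2)n1`) gives 1.2 h and compound 2 (`OC[C@@H](O)[C@@H](O)[C@H](O)c1c[nH]c(C(F)(F)C(F)(F)F)n1`) gives 1.7 h in the same read-out, two values within the scatter of each other. Among the compounds with values here, the one measured step is a 3.7-fold lower number from compound 1 to compound 3 (0.56 log units; beyond the scatter) and lies beyond the scatter, with 1,3-oxazol-4-yl in place of 1-hydroxyethyl on an aromatic carbon. The change to compound 4 (`Cn1cnc(-c2nc([C@@H](O)[C@H](O)[C@H](O)CO)c[nH]2)c1`) is 1-methyl-1H-imidazol-4-yl in place of 1,3-oxazol-4-yl on an aromatic carbon on an aromatic carbon, between two ring nitrogen atoms. The measured step replaced 1-hydroxyethyl rather than one five-membered aromatic ring with another, so it bears only loosely here. Compound 2 at 1.7 h and compound 3 at 1.2 h carry different groups in this place and still stay within the scatter of each other. The expected step, a 1.2-fold higher number from compound 3 to compound 4 (0.07 log units; within the scatter) in this assay, therefore stays within the scatter, with no firm direction. Compound 4 is estimated at 1.4 h with an expected range from 0.7 h to 3 h as a working figure.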

Compound 4, half-life: 1.6 h
The estimate for compound 4 lay 1.1-fold (0.06 log units) below the measured number, and the stated range covers the measured number.
By their numbers in this assay, from the lowest: compounds 3, 4 and 2 (each within the scatter of the next); then compound 1.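

In this assay, the 1-methyl-1H-imidazol-4-yl group in place of 1,3-oxazol-4-yl leaves the two compounds within the scatter (a 1.3-fold higher number from compound 3 to compound 4 (0.12 log units; within the scatter)), so this exchange of one five-membered aromatic ring with 2 hetero atoms for another, with one more heavy atom, does not separate them. The comparison with 1-hydroxyethyl now rests on a second aromatic ring, and it again lies beyond the scatter (a 2.8-fold lower number from compound 1 to compound 4 (0.44 log units; beyond the scatter)), so the lower number of compound 3 against compound 1 is not confined to 1,3-oxazol-4-yl. Nothing available bears on the reason for either step.

Open, on these data alone, is whether the longer half-life of compound 1 (4.4 h) depends on the hydroxyl group of 1-hydroxyethyl or on the absence of an aromatic ring at this carbon. A 1-methoxyethyl group, a 1-aminoethyl group or a six-membered pyridine ring in this place would help to tell these apart.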